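A thiazole group takes the place of a pyridine group

The source may report more compounds than this note shows. Statements on the series, on what has been measured and on what is new or still open speak of the compounds shown alone.

In a functional assay for inhibition, with Homo sapiens as the target (on this read-out lower numbers stand for stronger inhibition and higher numbers for weaker inhibition), compound 1 `CC(C)(C)Sc1c(CC(C)(C)C(=O)O)n(Cc2ccc(Cl)cc2)c2ccc(OCc3nc4ccccc4s3)cc12` gives 3 nM, compound 2 `CC(COc1ccc2c(c1)c(SC(C)(C)C)c(CC(C)(C)C(=O)O)n2Cc1ccc(Cl)cc1)c1ccccn1` gives 4 nM and compound 3 `C[C@@H](COc1ccc2c(c1)c(SC(C)(C)C)c(CC(C)(C)C(=O)O)n2Cc1ccc(Cl)cc1)c1ccccn1` gives 2 nM, which puts compound 3 within the scatter of both others. Compound 4 `CC(C)c1csc(COc2ccc3c(c2)c(SC(C)(C)C)c(CC(C)(C)C(=O)O)n3Cc2ccc(Cl)cc2)n1` is still unmeasured, and it differs from compound 3 on a saturated chain carbon bound to an oxygen on an aromatic ring: 4-isopropyl-1,3-thiazol-2-yl in place of 1-(pyridin-2-yl)ethyl on a saturated chain carbon bound to an oxygen on an aromatic ring. Two earlier exchanges at this place bear on it, a 1.3-fold higher number from compound 1 to compound 2 (0.12 log units; within the scatter) and a 1.5-fold lower number from compound 1 to compound 3 (0.18 log units; within the scatter), and both stay within the scatter. The step in drawn configuration, a 2.0-fold lower number from compound 2 to compound 3 (0.30 log units; within the scatter), does too. No change beyond the scatter is therefore expected in this assay, and the expected step is a 1.5-fold higher number from compound 3 to compound 4 (0.18 log units; within the scatter). For compound 4 the estimate is 3 nM, with an expected range from 1 nM to 9 nM.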

Compound 4, half-maximal inhibitory concentration: 3 nM
Compound 4: the middle estimate sits on the measured number at the digits printed; measured number inside the range.
By their numbers in this assay, from the lowest: compounds 3, 1, 4 and 2 (each within the scatter of the next).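

In this assay, the place on a saturated chain carbon bound to an oxygen on an aromatic ring also takes 4-isopropyl-1,3-thiazol-2-yl, with a 1.5-fold higher number from compound 3 to compound 4 (0.18 log units; within the scatter) and a 1.3-fold lower number from compound 2 to compound 4 (0.12 log units; within the scatter). Against 1,3-benzothiazol-2-yl there is no change at the digits printed from compound 1 to compound 4 (within the scatter). So among these four compounds, a five-membered aromatic ring with 2 hetero atoms and no defined stereocentre keeps the number within the scatter, just as the earlier groups did.

Going by these compounds, whether a group carrying an amine or a carboxylic acid at this place would do the same stays open. Nothing given here explains why these exchanges stay within the scatter.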